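The source may hold more compounds than are shown below. What is called first, only, known or untested is meant among the compounds shown, and "the series" means these compounds.

Measured compounds:
- compound 1 `C=Cc1ccc(S(=O)(=O)Nc2ccc3oc(-c4ccccc4)nc3c2)cc1`: in an ADME assay on HEK293 cells (Homo sapiens) for cytotoxicity, read by resazurin assay, with a stated time of 48 h (a lower number here means that less compound is tolerated, a higher number that more compound is tolerated), compound 1 gives 53000 nM
- compound 2 `O=S(=O)(Nc1ccc(-c2nc3ccccc3o2)cc1)c1ccc(F)c(C(F)(F)F)c1`: in this assay compound 2 gives 82000 nM
- compound 3 `O=S(=O)(Nc1ccc(-c2nc3ccccc3o2)cc1)c1ccccc1F`: in this assay compound 3 reaches the assay limit > 100000 nM, a limit rather than a number

Notes on the series. Compound 1 holds the lowest of the two numbers measured; the nearest is compound 2, a difference within the scatter, so the two are not told apart. The limit value of compound 3 stands as described in the limit of > 100000 nM in this assay, at which 1 of the 3 values shown sits, and is not a number. Going by the values given here, no pair of measured compounds differs in one place, so no measured step is available.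

Compound 4 `CS(=O)(=O)Nc1ccc2oc(-c3ccccc3)nc2c1` is not yet measured. From compound 1 it differs by methyl in place of 4-vinylphenyl on a sulfonyl sulfur. Among the compounds with values here, since no comparable step has been measured, the expected direction rests on the low cytotoxicity seen across the series. The step from compound 1 to compound 4 is expected to be a 1.6-fold higher number from compound 1 to compound 4 (0.21 log units; within the scatter), a modest rise toward more tolerated, though within or near the scatter. For compound 4 the estimate in this assay is 85000 nM, between 40000 nM and 200000 nM.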

Compound 4, half-maximal cytotoxic concentration: > 100000 nM
Compound 4: only a limit was reported; the forecaster's own chance of this, stated with the estimate: 45%; middle value at least 1.1-fold (0.07 log units) away from the limit.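

In this assay, going by these compounds alone, the only measured change on the sulfonyl sulfur is an at least 1.8-fold higher number from compound 1 to compound 4 (0.27 log units; that floor lies within the scatter), so the step has a floor but no measured size, and it cannot be separated from the scatter. Exchanging 4-vinylphenyl for methyl removes the six-membered aromatic ring and the double bond outside it, and this change gives no sign of lower tolerance at this position. The value of compound 4 is a limit and not a number: the limit of > 100000 nM in this assay, at which 2 of the 4 values shown sit.

Open, from the compounds shown here alone, is whether a plain phenyl, or a longer chain such as butyl, on the sulfonyl sulfur gives a number short of the limit. Also open, going by these compounds, is whether the vinyl group or the aromatic ring matters for the value of compound 1.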